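The source may report more compounds than this note shows. Statements on the series, on what has been measured and on what is new or still open speak of the compounds shown alone.

Measured in a functional assay on the whole organism with Scenedesmus acutus as the target, with a stated time of 20 h; a lower number here means a stronger inhibitor, a higher number a weaker inhibitor:
- compound 1 `COC(=O)c1cc(N2C(=O)C3=C(CCCC3)C2=O)ccc1Cl`: 1620 nM
- compound 2 `CCOC(=O)c1cc(N2C(=O)C3=C(CCCC3)C2=O)ccc1Cl`: 2140 nM
- compound 3 `CCCOC(=O)c1cc(N2C(=O)C3=C(CCCC3)C2=O)c(F)cc1Cl`: 66.1 nM

Compound 3, at 66.1 nM, has the lowest of the three numbers, and its gaps to compound 1 and compound 2 both lie beyond the scatter. The next compound is compound 4 `CCCOC(=O)c1cc(N2C(=O)C3=C(CCCC3)C2=O)ccc1Cl`, which keeps the propoxycarbonyl group of compound 3 and differs from it in one place: hydrogen in place of fluoro on an aromatic carbon. In words, hydrogen replaces fluoro on an aromatic carbon.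

Going by the values given here, no measured pair isolates this change. Among the compounds with values here, the only measured step is a 1.3-fold higher number from compound 1 to compound 2 (0.12 log units; within the scatter), which lies within the scatter and concerns the ester chain, not the aromatic carbon. It does suggest that chain length matters little between these two compounds. Compound 1 at 1620 nM and compound 2 at 2140 nM both carry hydrogen at the place in question, as compound 4 will, though their ester chains differ from its propoxycarbonyl group. Compound 4 is therefore expected to sit close to these two in this assay, as a weaker inhibitor than compound 3. The expected step is a 27-fold higher number from compound 3 to compound 4 (1.44 log units; beyond the scatter), well beyond the scatter. This remains an inference, since the chain and the fluoro differ together between compound 3 and the other two. For compound 4 the estimated value is 1800 nM, with an expected range of 600 nM to 4500 nM.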

Compound 4, half-maximal inhibitory concentration: 661 nM
Compound 4: middle estimate off by 2.7-fold (0.44 log units), on the high side, and the stated range covers the measured number.
By their numbers in this assay, from the lowest: compound 3; then compound 4; then compounds 1 and 2 (each within the scatter of the next).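

In this assay the fluoro on the aromatic carbon para to a propoxycarbonyl group now has a direct reading: with the propoxycarbonyl group held constant, hydrogen in place of fluoro gives a 10-fold higher number from compound 3 to compound 4 (1.00 log units; beyond the scatter) and so accounts for a real share of the low number of compound 3. The ester chain also proves to matter once it reaches the propoxycarbonyl group, even though a 1.3-fold higher number from compound 1 to compound 2 (0.12 log units; within the scatter) showed no readable change between the two shorter chains; with hydrogen on the aromatic carbon throughout, the series gives a 3.2-fold lower number from compound 2 to compound 4 (0.51 log units; beyond the scatter) and a 2.5-fold lower number from compound 1 to compound 4 (0.39 log units; beyond the scatter) as modest steps beyond the scatter. No supporting data bear on why either the fluoro or the longer ester chain moves the number in this way.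

The compounds shown leave open whether the fluoro step keeps its size on the shorter ester chains of compound 1 and compound 2, since fluoro appears here only with the propoxycarbonyl group. They also leave open how a longer chain such as butoxycarbonyl would read, and whether chloro or methoxy at the aromatic carbon would match fluoro.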